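The source may hold more compounds than are shown below. What is called first, only, known or untested is meant among the compounds shown, and "the series" means these compounds.

Compound 1, `CN(Cc1cn(CC(O)COC(=O)C2CCCCC2)nn1)CC1CCCCC1`: 18%
Compound 2, `CN(Cc1cn(CC(O)COC(=O)c2ccccc2)nn1)CC1CCCCC1`: 6%
Compound 3, `CCCCC(O)Cn1cc(CN(C)CC2CCCCC2)nn1`: 47%

In an assay on nucleic acid for inhibition of Nucleic Acid, read by fluorescence, tested at 100 uM (a higher number here means more inhibition at the concentration tested (going by the name of the read-out), a lower number less inhibition), compound 2 gives 6%, the lowest of the three numbers. The step of a number 12 percentage points lower from compound 1 to compound 2 (beyond the scatter) separates it from compound 1, and the step of a number 41 percentage points higher from compound 2 to compound 3 (beyond the scatter) separates it from compound 3, which stands furthest from it.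

Compound 4, `CC(C)CCN(C)Cc1cn(CC(O)COC(=O)c2ccccc2)nn1`, differs from compound 2 in one place: isobutyl in place of cyclohexyl on a saturated chain carbon bound to an amine nitrogen

Within the data shown here, none of the measured steps touches this position. The steps of a number 12 percentage points lower from compound 1 to compound 2 (beyond the scatter), a number 29 percentage points higher from compound 1 to compound 3 (beyond the scatter) and a number 41 percentage points higher from compound 2 to compound 3 (beyond the scatter) all change the group on the saturated chain carbon two bonds along the chain from the oxygen, while the amine side, carrying the cyclohexylmethyl group, is the same in compounds 1, 2 and 3. There is therefore no measured guide to how this assay responds to a change on the amine side. With nothing pointing in either direction, the step of a number 2 percentage points higher from compound 2 to compound 4 (within the scatter) is expected to lie within the scatter. Compound 4 is estimated to give 8% in this assay, with a range from 0% to 25%.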

Compound 4, a percentage reported as inhibition, at one concentration (the size of the read-out at that concentration, not a potency): 0%
Beside the measured number, compound 4's estimate is 8 percentage points above it, and the stated range covers the measured number.
By their numbers in this assay, from the lowest: compounds 4 and 2 (each within the scatter of the next); then compound 1; then compound 3.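

In this assay, among these compounds, the step of a number 6 percentage points lower from compound 2 to compound 4 (within the scatter) gives the first reading on the amine side, a part that stays the same in compounds 1, 2 and 3. With isobutyl in place of cyclohexyl on a saturated chain carbon bound to an amine nitrogen, the ring is gone, yet the two numbers stand within the scatter of each other, so on the benzoyloxy background this change shows no response that can be told from noise, and both numbers lie close to the floor of the read-out. Nothing measured here bears on the reason for this result.

On these data alone, whether the same change would register on a background with a higher number, such as that of compound 3, stays open. Also open, as far as these compounds go, is what a benzyl group, a morpholine ring or a longer alkyl chain would give on this amine.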